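The source may hold more compounds than are shown below. What is called first, only, known or untested is meant among the compounds shown, and "the series" means these compounds.

In an ADME assay on liver for metabolic stability, with Liver microsome (Homo sapiens) as the target, read by LC-MS, using microsomes, tested at 1 uM (a lower number here means that the compound disappears faster, a higher number that the compound lasts longer), compound 1 `Cc1cc(CCC#N)cc(C)c1Oc1cc(Nc2ccc(C#N)cc2)c(N)cc1C(=O)N(C)C` gives 1.65 h, compound 2 `CCNC(=O)c1cc(N)c(Nc2ccc(C#N)cc2)cc1Oc1c(C)cc(CCC#N)cc1C` gives 2.88 h and compound 3 `Cc1cc(CCC#N)cc(C)c1Oc1cc(Nc2ccc(C#N)cc2)c(N)cc1CN(C)C` gives 3.85 h. Going by the values given here, compound 3 holds the highest of the three numbers, though its margin over compound 2 is small: the step of a 1.3-fold higher number from compound 2 to compound 3 (0.13 log units; within the scatter) is within the scatter, as is a 1.7-fold higher number from compound 1 to compound 2 (0.24 log units; within the scatter), while a 2.3-fold higher number from compound 1 to compound 3 (0.37 log units; beyond the scatter) is the only step that reaches beyond it. Compound 4 `Cc1cc(CCC#N)cc(C)c1Oc1cc(Nc2ccc(C#N)cc2)c(N)cc1CNC1CC1` differs from compound 3 by cyclopropylamino in place of dimethylamino on a saturated chain carbon bound to an aromatic carbon. Among the compounds with values here, no measured step bears directly on this change: the steps of a 2.3-fold higher number from compound 1 to compound 3 (0.37 log units; beyond the scatter) and a 1.3-fold higher number from compound 2 to compound 3 (0.13 log units; within the scatter) replaced an amide by the (dimethylamino)methyl group, and a 1.7-fold higher number from compound 1 to compound 2 (0.24 log units; within the scatter) swapped one substituent on the carbonyl carbon for another, so all of them touch a different kind of group. The data therefore give no footing for a shift in either direction, and the change itself is confined to the substituents on a single nitrogen. Compound 4 is consequently expected to show a 1.1-fold lower number from compound 3 to compound 4 (0.04 log units; within the scatter), a step not beyond the scatter. In this assay compound 4 is estimated at 3.5 h, with a range from 1.8 h to 7 h.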

Compound 4, half-life in the Liver microsome assay: 1.65 h
Estimate against measurement, compound 4: 2.1-fold (0.33 log units) above; measured number below the stated range.
By their numbers in the Liver microsome assay, from the lowest: compounds 1, 4, 2 and 3 (each within the scatter of the next, the first and the last beyond it).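

Going by these compounds alone, in the Liver microsome assay the substituents on this one nitrogen turn out to matter: compound 3 gives 3.85 h and compound 4 gives 1.65 h, so that a 2.3-fold lower number from compound 3 to compound 4 (0.37 log units; beyond the scatter) is the first measured step at this place, and cyclopropylamino in place of dimethylamino carries it beyond the scatter. The new compound also changes how the amine series reads against the amides, for a 1.7-fold lower number from compound 2 to compound 4 (0.24 log units; within the scatter) and no change at the digits printed from compound 1 to compound 4 (within the scatter) show that a (cyclopropylamino)methyl group gives no separation from either amide, so the gap seen earlier between compound 1 and compound 3 does not hold for every aminomethyl group in place of the amide. Nothing at hand accounts for the step at this nitrogen.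

The compounds shown leave open whether the lower number goes with the three-membered ring or with the hydrogen-bond donor that enters with it, a question on which isopropylamino, with no ring, or azetidine, with no such hydrogen, would bear on the same carbon. As far as these compounds go, in a physicochemical assay for solubility, read by HPLC, in phosphate buffer, with a stated time of 4 h, at pH 7.4, tested at 10 mg/mL (on this read-out higher numbers stand for higher solubility and lower numbers for lower solubility), compound 3 gives 23.4 ug/mL and compound 4 gives 13.6 ug/mL, and there is a 1.7-fold lower number from compound 3 to compound 4 (0.24 log units; within the scatter) at the same place, so whether that read-out responds to this change at all also remains open.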